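Swapping a Ring for a Chain on the Shared Core

The source may hold more compounds than are shown below. What is called first, only, known or untested is meant among the compounds shown, and "the series" means these compounds.

For the measured compounds named here, compound 2 `O/N=C(\Nc1ccc(F)c(Br)c1)c1nonc1NCCn1cc(C2(O)CCCCC2)nn1` is one of two compounds so far tested in an assay on isolated protein for inhibition of Indoleamine 2,3-dioxygenase 1 (Homo sapiens); on this read-out higher numbers stand for weaker inhibition and lower numbers for stronger inhibition. In this assay compound 2 gives 62 nM, the lowest of the two numbers. Its nearest neighbour is compound 1 `OCCCCc1cn(CCNc2nonc2/C(=N/O)Nc2ccc(F)c(Br)c2)nn1`, which in this assay gives 80 nM; the step of a 1.3-fold lower number from compound 1 to compound 2 (0.11 log units; within the scatter) lies within the usual scatter, so the two compounds cannot be told apart on these numbers.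

Compound 3 `CC(C)(OCCO)c1cn(CCNc2nonc2/C(=N/O)Nc2ccc(F)c(Br)c2)nn1` has not yet been measured. It differs from compound 2 in one place: 1-(2-hydroxyethoxy)-1-methylethyl in place of 1-hydroxycyclohexyl on an aromatic carbon. Going by the values given here, the one measured step that bears on this change, a 1.3-fold lower number from compound 1 to compound 2 (0.11 log units; within the scatter), also exchanged the group on this same aromatic carbon and stayed within the scatter. That single step is thin evidence, and it involved a different pair of groups, but nothing in the data points to a large move in either direction.

With only that to go on, compound 3 is expected to sit close to compound 2, the step of a 1.1-fold higher number from compound 2 to compound 3 (0.05 log units; within the scatter) being expected to remain within the scatter. The estimate for compound 3 in this assay is therefore 70 nM, with a range from 25 nM to 200 nM.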

Compound 3, half-maximal inhibitory concentration: 176 nM
The estimate for compound 3 lay 2.5-fold (0.40 log units) below the measured number; the range from low to high includes it.
By their numbers in this assay, from the lowest: compounds 2 and 1 (each within the scatter of the next); then compound 3.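

In this assay, the group on this aromatic carbon can move the number after all: 1-(2-hydroxyethoxy)-1-methylethyl gives a 2.8-fold higher number from compound 2 to compound 3 (0.45 log units; beyond the scatter) and likewise a 2.2-fold higher number from compound 1 to compound 3 (0.34 log units; beyond the scatter), both modest but beyond the scatter, whereas the earlier exchange of 1-hydroxycyclohexyl for 4-hydroxybutyl, a 1.3-fold lower number from compound 1 to compound 2 (0.11 log units; within the scatter), could not be told apart from noise. The entering group matches 1-hydroxycyclohexyl in heavy atoms and hydrogen-bond donors, yet it has no ring and carries 2 hydrogen-bond acceptors in place of 1, so equal heavy-atom count alone does not keep the number in place, and losing the ring cannot be the whole story, since compound 1 also has no ring and stays within the scatter of compound 2. No measurement in hand accounts for the rise.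

As far as these compounds go, what remains open is which part of the entering group goes with the higher number: a 1-hydroxy-1-methylethyl group, lacking the ethoxy link, or a 1-methoxy-1-methylethyl group, lacking the terminal hydroxyl, would help to separate the two. The compounds shown also leave unknown how an amine or a carboxylic acid at the end of such a chain would read in this assay.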